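The source may report more compounds than this note shows. Statements on the series, on what has been measured and on what is new or still open speak of the compounds shown alone.

Measured in a toxicity assay on microsomes from liver (Homo sapiens) for metabolic stability, read by LC-MS, using NADPH, tested at 1 uM; a lower number here means slower removal, a higher number faster removal of the compound:
- compound 1 `C[C@@H]1CN(c2scnc2-c2nc3ccccc3[nH]2)CCN1C(=O)Cn1cnc2cccnc21` gives 12 mL.min-1.g-1
- compound 2 `CCOc1ncc(-c2nc(C(F)(F)F)sc2N2CCN(C(=O)Cn3ccc4cccnc43)[C@H](C)C2)cn1` gives 316 mL.min-1.g-1
- compound 3 `CCOc1ncc(-c2nc(C(F)(F)F)sc2N2CCN(C(=O)Cn3ccc4cnccc43)[C@H](C)C2)cn1` gives 656 mL.min-1.g-1

Compound 3 has the highest of these three numbers in this assay, and compound 1 has the lowest. Compound 4 `CCOc1ncc(-c2nc(C(F)(F)F)sc2N2CCN(C(=O)Cn3nccc3C)[C@H](C)C2)cn1` has not yet been measured. It differs from compound 3 in one group: a group of 6 heavy atoms (4 carbon, 2 nitrogen; one five-membered aromatic ring with 2 hetero atoms) in place of a group of 9 heavy atoms (7 carbon, 2 nitrogen; one five-membered aromatic ring with 1 hetero atom, one six-membered aromatic ring with 1 hetero atom), on a saturated chain carbon bound to a carbonyl carbon, the entering group being 5-methyl-1H-pyrazol-1-yl.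

Among the compounds with values here, one measured step bears on this place, a 2.1-fold higher number from compound 2 to compound 3 (0.32 log units; beyond the scatter), in which the group was exchanged for another with the same counts. That step is modest, and it involves no group of the smaller kind that enters here, so it is only a loose guide. Compound 1, at 12 mL.min-1.g-1, differs from compound 3 in more than this group and offers no clean comparison.

A modest step to a lower number is therefore expected, with the direction uncertain, and the expected change is a 2.3-fold lower number from compound 3 to compound 4 (0.37 log units; beyond the scatter) in this assay. The estimate for compound 4 is 280 mL.min-1.g-1, with an expected range from 100 mL.min-1.g-1 to 700 mL.min-1.g-1 as its limits.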

Compound 4, intrinsic clearance in microsomes: 65 mL.min-1.g-1
Beside the measured number, compound 4's estimate is 4.3-fold (0.63 log units) above it; measured number outside the range, below it.
By their numbers in this assay, from the lowest: compound 1; then compound 4; then compound 2; then compound 3.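

With 5-methyl-1H-pyrazol-1-yl on the saturated chain carbon bound to a carbonyl carbon, this assay gives a clear fall against both larger groups: a 10-fold lower number from compound 3 to compound 4 (1.00 log units; beyond the scatter) and a 4.9-fold lower number from compound 2 to compound 4 (0.69 log units; beyond the scatter) are the two steps. The earlier exchange between groups with the same counts had shown only a modest shift at this place, whereas a smaller ring here gives compound 4 the lowest number of the three compounds that share this core. Nothing measured here explains this fall.

It remains open whether the fall belongs to the methyl or to the pyrazole ring itself, since neither an unsubstituted pyrazol-1-yl group nor an ethyl or methoxy group on that ring appears among these compounds. The compounds shown also leave open whether 5-methyl-1H-pyrazol-1-yl would give a similar fall on the core of compound 1, which already stands at 12 mL.min-1.g-1 in this assay.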